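A few compounds are considered here, and "the series" means these few. Any claim that something is new, unique, unknown or untested is made for them only; others in the source may bear on it.

Compound 2 `COc1ccccc1NC1=CC(=O)c2c(nc3n2[C@H]2OC[C@@H](O)[C@H]2OC3)C1=O` gives 6580 nM in a functional assay on MCF7 cells (Homo sapiens) for inhibition, read by sulforhodamine B assay (on this read-out lower numbers stand for stronger inhibition and higher numbers for weaker inhibition), the higher of the two numbers shown, with compound 1 `Cc1ccc(NC2=CC(=O)c3nc4n(c3C2=O)[C@H]2OC[C@@H](O)[C@H]2OC4)cc1` at 1660 nM. Compound 3 `O=C1C=C(NC2CCCC2)C(=O)c2c1nc1n2[C@H]2OC[C@@H](O)[C@H]2OC1` reaches only the limit of > 16000 nM in this assay. Compound 4 `O=C1C(NCc2ccccc2)=CC(=O)c2c1nc1n2[C@H]2OC[C@@H](O)[C@H]2OC1` differs from compound 2 by benzyl in place of 2-methoxyphenyl on an amine nitrogen. Within the data shown here, the one measured step that bears on taking an aromatic ring off the amine nitrogen is an at least 9.6-fold higher number from compound 1 to compound 3 (0.98 log units; beyond the scatter), where the value of compound 3 sat at the limit of > 16000 nM in this assay, at which 1 of the 3 values shown sits. Benzyl keeps an aromatic ring, unlike cyclopentyl, so for compound 4 a smaller loss is expected, a 1.8-fold higher number from compound 2 to compound 4 (0.26 log units; within the scatter). Compound 4 is therefore estimated at 12000 nM, within 4000 nM to 30000 nM, in this assay.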

Compound 4, half-maximal inhibitory concentration: > 8000 nM
Compound 4: no number, only a limit (the forecaster's own chance of this, stated with the estimate: 35%); the middle value lies beyond the limit too.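

In this assay compound 4 gives > 8000 nM, which is a limit and not a number. The step reads an at least 1.2-fold higher number from compound 2 to compound 4 (0.08 log units; that floor lies within the scatter), so benzyl in place of 2-methoxyphenyl on an amine nitrogen has only a floor, and that floor does not separate the two compounds. Benzyl keeps an aromatic ring on this nitrogen, yet compound 4 ends at a limit, as compound 3 with cyclopentyl does: the limit of > 8000 nM in this assay, at which 1 of the 4 values shown sits.

On these data alone, how far compound 4 lies past its limit stays open, as does whether benzyl and cyclopentyl differ at all. So does what a longer chain, such as 2-phenylethyl, would give on the amine nitrogen.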